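A few compounds are considered here, and "the series" means these few. Any claim that something is new, unique, unknown or untested is made for them only; others in the source may bear on it.

Compound 1 `CSc1ccc2c(c1)c(O)c(C(=O)N(C)c1ccccc1)c(=O)n2C`, compound 2 `CN1C(=O)/C(=C(/S)N(C)c2ccccc2)C(=O)c2cc(Br)ccc21` and compound 3 `COc1ccc(N(C)/C(S)=C2/C(=O)c3cc(Cl)ccc3N(C)C2=O)cc1` share one core and have all been run in a functional assay on the whole organism for inhibition, with Mus musculus as the target, at a dose of 10 mg/kg by the oral route; on this read-out lower numbers stand for less inhibition and higher numbers for more inhibition at the one dose given (going by the name of the read-out). In this assay compound 1 gives 67%, compound 2 gives 56% and compound 3 gives 45%. Compound 3 stands lowest of the three numbers: its nearest neighbour is compound 2, whose value is higher by an amount beyond the scatter, and compound 1 lies further off, also beyond the scatter.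

Compound 4 `CN1C(=O)/C(=C(/S)N(C)c2ccc(Cl)cc2)C(=O)c2cc(Cl)ccc21` has not yet been measured in this assay. It differs from compound 3 in one place: chloro in place of methoxy on an aromatic carbon. For the measured compounds named here, no pair of measured compounds is separated by this same change, so its effect in this assay cannot be read from the data in hand. The expectation is a step of no size beyond the scatter, in neither direction. Compound 4 is expected to show a step of a number 5 percentage points higher from compound 3 to compound 4 (within the scatter). Compound 4 is estimated at 50% in this assay, with a range from 30% to 70%.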

Compound 4, a percentage reported as inhibition, in the whole organism at one dose (the size of the read-out at that dose, not a potency): 47%
For compound 4 the middle estimate is 3 percentage points above the measured one; measured number inside the range.
By their numbers in this assay, from the lowest: compounds 3, 4 and 2 (each within the scatter of the next, the first and the last beyond it); then compound 1.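

Chloro in place of methoxy, on an aromatic carbon para to a large group, gives in this assay a number 2 percentage points higher from compound 3 to compound 4 (within the scatter), the only one-place comparison available so far. With the rest of the structure held fixed, this change from 4-methoxyphenyl to 4-chlorophenyl therefore leaves the read-out at this one dose unresolved, and neither group can be ranked over the other at this position. No accompanying measurement bears on this result.

From the compounds shown here alone, whether an amine, a carboxylic acid or a longer chain such as butoxy at this position would produce a step beyond the scatter remains open. Going by these compounds, it is also open whether chloro in place of methoxy would give a similar step with a different substituent elsewhere on the shared core.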